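Series notes: aryl swap on the ethoxy side chain

A few compounds are considered here, and "the series" means these few. Any claim that something is new, unique, unknown or untested is made for them only; others in the source may bear on it.

Compound 1 `COc1ccc(CCOc2ccc(-c3c(C)nc(C)c([C@H](OC(C)(C)C)C(=O)O)c3N3CCC(C)(C)CC3)cc2)cc1` and compound 2 `COc1cccc(CCOc2ccc(-c3c(C)nc(C)c([C@H](OC(C)(C)C)C(=O)O)c3N3CCC(C)(C)CC3)cc2)c1` share one core and differ only in the aryl group on a saturated chain carbon, two bonds along the chain from an oxygen on an aromatic ring. In an ADME assay on microsomes from liver (Rattus norvegicus) for metabolic stability, read by LC-MS, tested at 0.5 uM (a higher number here means that the compound lasts longer, a lower number that the compound disappears faster), compound 1 gives > 2 h, which is a limit of the assay and not a number. Compound 2 likewise gives > 2 h in this assay, again a limit rather than a number. The step that the two limits leave unreadable from compound 1 to compound 2 is therefore unreadable, both values sitting at the limit of > 2 h in this assay, at which 2 of the 2 values shown sit. Compound 2 thus stands at the limit of this assay, with no number of its own to place it more finely.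

Compound 3 `Cc1cc(CCOc2ccc(-c3c(C)nc(C)c([C@H](OC(C)(C)C)C(=O)O)c3N3CCC(C)(C)CC3)cc2)ccc1F` is the next variation: 4-fluoro-3-methylphenyl in place of 3-methoxyphenyl on a saturated chain carbon, two bonds along the chain from an oxygen on an aromatic ring. For the measured compounds named here, the one measured step concerns the same position but its size is unreadable, so it gives no direction for the step in this assay. The step from compound 2 to compound 3 is expected to be a step that the limit leaves unreadable from compound 2 to compound 3, a change not expected to exceed the usual scatter. Compound 3 is estimated at 2.5 h, within 1 h to 6 h, with a fair chance that this assay again reports only a limit.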

Compound 3, half-life: > 2 h
Compound 3: a limit, no number; the forecaster's own chance of this, stated with the estimate: 60%; the middle value does not contradict the limit.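

Compound 3 gives > 2 h in this assay as a limit, not a number. For the compounds shown here, no step among compound 1, compound 2 and compound 3 can be read, as all values sit at one limit: the limit of > 2 h in this assay, at which 3 of the 3 values shown sit. Going by these compounds, whether 4-methoxyphenyl, 3-methoxyphenyl and 4-fluoro-3-methylphenyl differ at all in this assay stays open, as does the size of any such difference.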